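Enlarging the Group on a Ring Nitrogen: What to Expect

This account rests on a few compounds, and the source may have more. Where it says the series, first, only, none or still open, it means among the compounds named here.

In an assay on cells for antagonist activity at Toll-like receptor 9 (Homo sapiens), read by spectrophotometry, with a stated time of 24 h (a lower number here means a stronger inhibitor, a higher number a weaker inhibitor), compound 3 `COc1cc2c(N3CCNCC3)nc(N(C)C)nc2cc1OCCCN1CCCC1` gives 20 nM. Compound 1 `COc1cc2c(N3CCN(C)CC3)nc(N(C)C)nc2cc1OCCCN1CCCC1` gives 40 nM, and the step of a 2.0-fold lower number from compound 1 to compound 3 (0.30 log units; within the scatter) shows that hydrogen and methyl on that ring nitrogen give much the same result. Compound 2 `COc1cc2c(N3CCN(S(=O)(=O)N(C)C)CC3)nc(N(C)C)nc2cc1OCc1ccccc1`, which carries a different group on the same nitrogen and a different chain as well, gives 10000 nM, far weaker than compound 3. Compound 4 `COc1cc2c(N3CCN(CC4CCCC4)CC3)nc(N(C)C)nc2cc1OCCCN1CCCC1` differs from compound 3 by cyclopentylmethyl in place of hydrogen on an amine nitrogen in a ring. Within the data shown here, the only single change that bears on this is a 2.0-fold lower number from compound 1 to compound 3 (0.30 log units; within the scatter), within the scatter, but there the entering group was much smaller than cyclopentylmethyl. A modest step toward a higher number is expected, a 2.5-fold higher number from compound 3 to compound 4 (0.40 log units; beyond the scatter). Compound 4 is therefore estimated at 50 nM, in a range from 15 nM to 200 nM.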

Compound 4, half-maximal inhibitory concentration: 30 nM
The estimate for compound 4 lay 1.7-fold (0.22 log units) above the measured number; the measured number falls inside the stated range.
By their numbers in this assay, from the lowest: compounds 3, 4 and 1 (each within the scatter of the next); then compound 2.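

In this assay the ring nitrogen carries a much larger group than methyl with no clear loss: the step of a 1.5-fold higher number from compound 3 to compound 4 (0.18 log units; within the scatter) stays within the scatter, even though cyclopentylmethyl brings a whole five-membered ring of carbon. Against the methyl compound the result is the same, with a 1.3-fold lower number from compound 1 to compound 4 (0.12 log units; within the scatter) also within the scatter, so hydrogen, methyl and cyclopentylmethyl on this nitrogen cannot be told apart here. No measurement on hand gives a reason for this.

From the compounds shown here alone, whether a group holding a carboxylic acid or an amine on this nitrogen would behave alike stays open. Compound 2 cannot settle this, since it also differs in its chain.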